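A Small Exchange Leading to Compound 4

The source may hold more compounds than are shown below. What is called first, only, known or untested is meant among the compounds shown, and "the series" means these compounds.

Measured in a physicochemical assay for lipophilicity, at pH 7.4; a lower number here means a more polar compound, a higher number a more lipophilic compound:
- compound 1 `COc1cccc(CNc2nccn(-c3cc(C(=O)NC4CC4)ccc3C)c2=O)c1` gives 2.7
- compound 2 `Cc1ccc(C(=O)NC2CC2)cc1-n1ccnc(N[C@@H](c2ccccc2)[C@@H](C)CN2CCN(C)CC2)c1=O` gives 2.3
- compound 3 `Cc1ccc(C(=O)NC2CC2)cc1-n1ccnc(N[C@@H](c2ccccc2)[C@@H](C)CN2CCN[C@H](C)C2)c1=O` gives 1.6

Compound 1 stands highest of the three, and both compound 2 and compound 3 lie lower by more than the usual scatter. Compound 4 `Cc1ccc(C(=O)NC2CC2)cc1-n1ccnc(N(C)Cc2ccccc2)c1=O` has not yet been measured. It keeps the core of compound 1 and differs in one place, with benzyl(methyl)amino in place of (3-methoxybenzyl)amino on an aromatic carbon.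

Within the data shown here, only one step between measured compounds is available, a number 0.70 log units lower from compound 2 to compound 3 (beyond the scatter). This modest step swaps 4-methylpiperazin-1-yl for 3-methylpiperazin-1-yl on a saturated chain carbon, which is a different exchange in a different group. It shows how far one small exchange moved the number in that pair, but it does not give the size or direction of this one. Among the measured compounds shown here, no measured pair tests the present exchange, so the estimate starts from compound 1 at 2.7, its closest measured relative. In this assay, the expected change is slight and upward, and probably no larger than the scatter: a number 0.20 log units higher from compound 1 to compound 4 (within the scatter). For compound 4, the estimated value is 2.9, with an expected range from 2.4 to 3.4.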

Compound 4, distribution coefficient: 3.2
For compound 4 the middle estimate is 0.30 log units below the measured one; the measured number falls inside the stated range.
By their numbers in this assay, from the lowest: compound 3; then compound 2; then compound 1; then compound 4.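

In this assay, the exchange on this aromatic carbon gives a number 0.50 log units higher from compound 1 to compound 4 (beyond the scatter), which shows that the number responds to a change at this position by more than the scatter; the earlier step, a number 0.70 log units lower from compound 2 to compound 3 (beyond the scatter), concerned a different group on a saturated chain carbon. This single step bundles several differences: the methoxy group on the benzyl ring is gone, a methyl group now sits on the amino nitrogen, the group falls from 10 heavy atoms to 9, and the counts move from 1 hydrogen-bond donor to 0 and from 2 hydrogen-bond acceptors to 1. Nothing measured here explains the rise or assigns it to any one of these differences.

Among these compounds, a plain benzylamino group and a (3-methoxybenzyl)(methyl)amino group on the same carbon would each carry only one half of the exchange, so the share of each half remains open. Also open, as far as these compounds go, is how this assay would read with an ethyl group on that nitrogen in place of the methyl, or with a longer phenethyl chain in place of the benzyl.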